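From 4-fluorophenyl to 2,4-dichlorophenyl

This account rests on a few compounds, and the source may have more. Where it says the series, first, only, none or still open, it means among the compounds named here.

In a functional assay on A549 cells (Homo sapiens) for antiproliferative activity, read by MTT assay, with a stated time of 72 h (on this read-out lower numbers stand for stronger inhibition and higher numbers for weaker inhibition), compound 3 `NC1=NC2(CCOCC2)N(OCCCOc2ccc(F)cc2)C(N)=N1` gives 1060 nM and sits level with compound 1 `NC1=NC2(CCOCC2)N(OCCCOc2ccccc2)C(N)=N1` at 1080 nM and far above compound 2 `NC1=NC2(CCOCC2)N(OCCCOc2cccc(Cl)c2Cl)C(N)=N1` at 100 nM on this scale. Compound 4 `NC1=NC2(CCOCC2)N(OCCCOc2ccc(Cl)cc2Cl)C(N)=N1` differs from compound 3 as 2,4-dichlorophenyl in place of 4-fluorophenyl on an oxygen on a saturated carbon with 2,4-dichlorophenyl in place of 4-fluorophenyl on an oxygen on a saturated carbon. Fluoro alone changed nothing beyond the scatter (a 1.0-fold lower number from compound 1 to compound 3 (0.01 log units; within the scatter)) while 2,3-dichlorophenyl gave large steps in both directions (an 11-fold lower number from compound 1 to compound 2 (1.03 log units; beyond the scatter); an 11-fold higher number from compound 2 to compound 3 (1.03 log units; beyond the scatter)). Compound 2 at 100 nM is the only dichlorophenyl measured, so a large step to a lower number is expected in this assay, though 2,4-dichlorophenyl itself remains unmeasured. The expected step is a 6.2-fold lower number from compound 3 to compound 4 (0.79 log units; beyond the scatter) here. The estimated value for compound 4 is 170 nM within a range of 60 nM to 480 nM on this scale.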

Compound 4, half-maximal inhibitory concentration: 70 nM
Beside the measured number, compound 4's estimate is 2.4-fold (0.39 log units) above it, and the stated range covers the measured number.
By their numbers in this assay, from the lowest: compounds 4 and 2 (each within the scatter of the next); then compounds 3 and 1 (each within the scatter of the next).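

In this assay, the large drop in the number is not confined to the 2,3-dichlorophenyl group: 2,4-dichlorophenyl on this oxygen also gives one, against both the phenyl (a 15-fold lower number from compound 1 to compound 4 (1.19 log units; beyond the scatter)) and the 4-fluorophenyl (a 15-fold lower number from compound 3 to compound 4 (1.18 log units; beyond the scatter)) groups. The change from 2,3-dichlorophenyl to 2,4-dichlorophenyl stays within the scatter (a 1.4-fold lower number from compound 2 to compound 4 (0.15 log units; within the scatter)), so these two dichlorophenyl groups stand level. Nothing given here explains the drop. Still open, as far as these compounds go, is whether a 4-chlorophenyl or a 2,4-dimethylphenyl group would give the same drop, and what a longer chain would do.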